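This account rests on a few compounds, and the source may have more. Where it says the series, first, only, none or still open, it means among the compounds named here.

Measured so far:
compound 1, `COc1cccc(N2CCN(C(=O)C(C)N3C(=O)CCC3=O)CC2)c1`: 0%
compound 2, `CCC(C(=O)N1CCN(c2ccccc2)CC1)N1C(=O)CCC1=O`: 25%

In a functional assay on the whole organism (strain Swiss) with Mus musculus as the target, in the maximal electroshock model, with a stated time of 2 h, at a dose of 300 mg/kg by the intraperitoneal route (a lower number here means a weaker effect, a higher number a stronger effect of the compound at the dose given), compound 1 gives 0%, the lowest of the two numbers seen. Compound 2 gives 25% in this assay, a number higher than that of compound 1 by more than the usual scatter. Compound 2 differs from compound 1 in more than one place, so its higher value cannot be tied to any single change.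

Compound 3, `CC(C(=O)N1CCN(c2ccccc2F)CC1)N1C(=O)CCC1=O`, is not yet measured in this assay. It differs from compound 1 in one place: 2-fluorophenyl in place of 3-methoxyphenyl on an amine nitrogen in a ring. The shared core stays as in compound 1; the 3-methoxyphenyl with its one hydrogen-bond acceptor gives way to a 2-fluorophenyl with none.

Going by the values given here, no measured step covers this exchange. Among the compounds with values here, the one higher number seen, that of compound 2 at 25%, comes with an aryl group lacking the methoxy and is weak support for a rise. A small step upward from compound 1 to compound 3, a number 15 percentage points higher from compound 1 to compound 3 (beyond the scatter), is expected, near the edge of the scatter. Compound 3 is estimated to give 15% in this assay, within 0% to 40%.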

Compound 3, a percentage reported as activity, at one dose (the size of the read-out at that dose, not a potency): 25%
The estimate for compound 3 lay 10 percentage points below the measured number, and the stated range covers the measured number.
By their numbers in this assay, from the lowest: compound 1; then compounds 2 and 3 (each within the scatter of the next).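

In this assay, 2-fluorophenyl in place of 3-methoxyphenyl on the amine nitrogen in the ring gives a number 25 percentage points higher from compound 1 to compound 3 (beyond the scatter). Going by these compounds alone, this is the first step that differs in one place, so the aryl group on this nitrogen can be said to change the read-out on the shared core, which the comparison with compound 2 could not show. The two aryl groups differ both in the substituent and in where it sits on the phenyl ring, and no information at hand accounts for the step.

Still open, going by these compounds, is how 3-fluorophenyl and 2-methoxyphenyl on the shared core would read in this assay, a pair that would separate the effect of the substituent from that of its place on the phenyl ring. Also open, on these data alone, is whether the same nitrogen tolerates other groups, such as a pyridyl ring or a benzyl group, and whether any of them would lift the read-out further at this dose.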